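The compounds below may be only part of what the source reports. "The series", "measured", "known", "first", "only" and "open" are said of these compounds alone.

Measured so far in a functional assay on HL-60 cells (Homo sapiens) for antiproliferative activity, with a stated time of 24 h; on this read-out lower numbers stand for stronger inhibition and higher numbers for weaker inhibition:
compound 1 `NC(=O)c1c(NC(=O)c2ccccc2Cl)sc2c1CCN(C(=S)Nc1ccccc1Br)C2`: 9090 nM
compound 2 `NC(=O)c1c(NC(=O)c2ccccc2Cl)sc2c1CCN(C(=S)Nc1ccccc1C(F)(F)F)C2`: 10600 nM
compound 3 `NC(=O)c1c(NC(=O)c2ccccc2Br)sc2c1CCN(C(=S)Nc1ccccc1Br)C2`: 17600 nM

Compound 2 differs from compound 1 by trifluoromethyl in place of bromo on an aromatic carbon; this change made a step of a 1.2-fold higher number from compound 1 to compound 2 (0.07 log units; within the scatter). Compound 3 carries the other core in the set: it differs from compound 1 by bromo in place of chloro on an aromatic carbon, a step of a 1.9-fold higher number from compound 1 to compound 3 (0.29 log units; within the scatter). All three values lie within the scatter of one another, so no order among compound 1, compound 2 and compound 3 is taken from them.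

Compound 4 `NC(=O)c1c(NC(=O)c2ccccc2Br)sc2c1CCN(C(=S)Nc1ccccc1C(F)(F)F)C2` has not yet been measured in this assay. It differs from compound 3 by trifluoromethyl in place of bromo on an aromatic carbon. The place of this change reads word for word as the place of the change from compound 1 to compound 2, so it is the same change, now made on the core of compound 3. For the measured compounds named here, only that one earlier instance is available, and the expectation rests on compound 1 and compound 2 and on a 1.2-fold higher number from compound 1 to compound 2 (0.07 log units; within the scatter). On that basis the expected step is a 1.2-fold higher number from compound 3 to compound 4 (0.08 log units; within the scatter), within the scatter. For compound 4 the estimated value in this assay is 21000 nM, with an expected range from 10000 nM to 45000 nM.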

Compound 4, half-maximal inhibitory concentration: 27400 nM
Compound 4: the middle estimate sits 1.3-fold (0.12 log units) below what was measured, within the range that was stated.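

Trifluoromethyl in place of bromo gives a 1.6-fold higher number from compound 3 to compound 4 (0.19 log units; within the scatter) in this assay, and this step agrees with the earlier instance on the other core: the same change on two cores in this assay, a 1.2-fold higher number (0.07 log units; within the scatter) from compound 1 to compound 2 and a 1.6-fold higher number (0.19 log units; within the scatter) from compound 3 to compound 4, 1.3-fold (0.13 log units) apart, within the scatter of two such steps

Bromo in place of chloro gives a 2.6-fold higher number from compound 2 to compound 4 (0.41 log units; beyond the scatter), a modest step beyond the scatter, yet it too agrees with its earlier instance, which lies within the scatter: the same change on two cores in this assay, a 1.9-fold higher number (0.29 log units; within the scatter) from compound 1 to compound 3 and a 2.6-fold higher number (0.41 log units; beyond the scatter) from compound 2 to compound 4, 1.3-fold (0.13 log units) apart, within the scatter of two such steps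

For the compounds shown here, each change therefore carries from one core to the other across these four compounds, but this rests on only two instances per change, all small steps in a single cell assay, so it shows neither a general rule for the series nor any reason for the agreement.

Going by these compounds, whether the agreement holds for larger steps stays open, for example with a methoxy, a nitrile, an amine or a carboxylic acid on the aromatic carbon that carries bromo or trifluoromethyl. Also open, on these data alone, is whether fluoro or methyl in place of chloro or bromo would carry between cores in the same way.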